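Methyl to isopropyl on the phenol ring of compound 1

The source may report more compounds than this note shows. Statements on the series, on what has been measured and on what is new or still open speak of the compounds shown alone.

Measured compounds:
- compound 1, `Cc1ccc(O)c(-c2nc(N[C@H]3CCNC3)c3ccccc3n2)c1`: 92 nM
- compound 2, `COC(=O)[C@@H]1C[C@H](Nc2nc(-c3ccccc3O)nc3ccccc23)CN1`: 4600 nM
- compound 3, `COc1cc2nc(-c3cc(F)ccc3O)nc(N[C@@H]3CNC[C@H]3CO)c2cc1OC`: 11 nM

In an assay on isolated protein for inhibition of serine/threonine-protein kinase Chk2 (Homo sapiens) (on this read-out higher numbers stand for weaker inhibition and lower numbers for stronger inhibition), compound 1 gives 92 nM. Among the three numbers this is the second highest: compound 3 gives 11 nM, a lower number that lies beyond the usual scatter, and compound 2 gives 4600 nM, the highest of the set and also beyond the scatter from compound 1. Compounds 2 and 3 differ from compound 1 in more than one place, so no single change can be read from their numbers.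

Compound 4, `CC(C)c1ccc(O)c(-c2nc(N[C@H]3CCNC3)c3ccccc3n2)c1`, is not yet measured. It differs from compound 1 in one place only: isopropyl in place of methyl on an aromatic carbon. Going by the values given here, no measured pair shows this change, so the size of the step cannot be taken from the series; the only anchor is compound 1 with 92 nM.

The expectation for the step from compound 1 to compound 4 in this assay is a small movement toward a higher number, a 1.4-fold higher number from compound 1 to compound 4 (0.15 log units; within the scatter), not clearly beyond the scatter. Compound 4 is estimated at 130 nM, with a range from 40 nM to 400 nM.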

Compound 4, half-maximal inhibitory concentration: 1700 nM
Estimate against measurement, compound 4: 13-fold (1.12 log units) below; measured number outside the range, above it.
By their numbers in this assay, from the lowest: compound 3; then compound 1; then compound 4; then compound 2.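

In this assay, the aromatic carbon para to a hydroxy group is sensitive to the alkyl group it carries: isopropyl in place of methyl gives an 18-fold higher number from compound 1 to compound 4 (1.27 log units; beyond the scatter). Going by these compounds alone, this is the only step that differs in one place, so it gives the first direct reading of this position; compound 2 and compound 3 differ from compound 1 in more than one place and could not isolate it. Neither methyl nor isopropyl brings a ring, a hydrogen-bond donor, a hydrogen-bond acceptor or a net charge, yet no measurement shown here accounts for the size of the step.

Going by these compounds, with only methyl and isopropyl seen at this position, it remains open whether an ethyl group would fall between compound 1 and compound 4, and whether a methoxy group, a hydroxymethyl group or a chlorine atom would read differently from an alkyl group. Also open, on these data alone, is whether isopropyl would produce a step of similar size on the core of compound 3 or with the side chain of compound 2.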